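A few compounds are considered here, and "the series" means these few. Any claim that something is new, unique, unknown or untested is made for them only; others in the source may bear on it.

In a physicochemical assay for lipophilicity, using the shake flask method, in phosphate buffer, measured as octanol-water partition, with a stated time of 30 min, at pH 7.4 (on this read-out lower numbers stand for lower lipophilicity and higher numbers for higher lipophilicity), compound 1 (`Cc1nc(CO)ccc1-c1cnc(NCc2c(F)ccc3c2CCO3)c2cn[nH]c(=O)c12`) gives 2.4 as its value. Compound 3 (`Cc1ncccc1-c1cnc(NCc2c(F)ccc3c2CCO3)c2n[nH]c(=O)n12`) gives 2.5 in this assay and so lies within the usual scatter of compound 1. Compound 2 (`Cc1ncccc1-c1cnc(NCc2c(F)ccc3c2CCO3)c2ncc(=O)[nH]c12`) gives 2.8, a number higher than that of compound 1 by more than the usual scatter, which leaves compound 1 in the lower part of this small set.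

Compound 4 (`CNC(=O)c1cc(-c2cnc(NCc3c(F)ccc4c3CCO4)c3cn[nH]c(=O)c23)n(C)n1`) has not yet been measured. It keeps the core of compound 1 and exchanges one group (1-methyl-3-(methylcarbamoyl)-1H-pyrazol-5-yl in place of 6-(hydroxymethyl)-2-methylpyridin-3-yl on an aromatic carbon) on an aromatic carbon: 1-methyl-3-(methylcarbamoyl)-1H-pyrazol-5-yl takes the place of 6-(hydroxymethyl)-2-methylpyridin-3-yl.

Going by the values given here, no pair of measured compounds differs in one place alone, so the data offer no direct guide to the size of this exchange. A small downward move is expected, probably not beyond the scatter, and the estimated step of a number 0.20 log units lower from compound 1 to compound 4 (within the scatter) is held with wide margins. For compound 4 the expected value is 2.2 with an estimated range from 1.7 to 2.7 in this assay when it is measured.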

Compound 4, distribution coefficient: 2.1
Compound 4: middle estimate off by 0.10 log units, on the high side; the measured number falls inside the stated range.
By their numbers in this assay, from the lowest: compounds 4, 1, 3 and 2 (each within the scatter of the next, the first and the last beyond it).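

Going by these compounds alone, this is the first step that can be read at this aromatic carbon: in this assay, 1-methyl-3-(methylcarbamoyl)-1H-pyrazol-5-yl in place of 6-(hydroxymethyl)-2-methylpyridin-3-yl gives a number 0.30 log units lower from compound 1 to compound 4 (within the scatter). So, on the core of compound 1, a five-membered aromatic ring with 2 hetero atoms can take the place of a six-membered aromatic ring with 1 hetero atom without a step beyond the scatter. Nothing measured here accounts for the size of this step.

The compounds shown leave open whether a carboxylic acid or an amine in place of the methylcarbamoyl group on this pyrazole would give a step beyond the scatter. They also leave open whether the same exchange would give a similar step on the cores of compound 2 and compound 3.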